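The compounds below may be only part of what the source reports. "The series", "measured", "known", "first", "only" and "open" are said of these compounds alone.

Measured in a functional assay on MDA-MB-231 cells (Homo sapiens) for antiproliferative activity, with a stated time of 4 days; on this read-out higher numbers stand for weaker inhibition and lower numbers for stronger inhibition:
- Compound 1 `COc1ccc(-c2[nH]c3ccc(C(C)C)cc3c2C=O)cc1`: 29 nM
- Compound 2 `CCCCc1ccc2[nH]c(-c3ccc(OC)cc3)c(C=O)c2c1`: 6.7 nM
- Compound 3 `COc1ccc(-c2[nH]c3ccc(C(C)(C)C)cc3c2C=O)cc1`: 280 nM

At 280 nM, compound 3 has the highest number of the three, which makes it the weakest inhibitor so far. Compound 4 `CCCCCCc1ccc2[nH]c(-c3ccc(OC)cc3)c(C=O)c2c1` has hexyl in place of tert-butyl on an aromatic carbon. The closest guide is the large step of a 42-fold higher number from compound 2 to compound 3 (1.62 log units; beyond the scatter), which, read in reverse, shows what replacing tert-butyl with butyl does. The modest steps of a 4.3-fold lower number from compound 1 to compound 2 (0.64 log units; beyond the scatter) and a 9.7-fold higher number from compound 1 to compound 3 (0.98 log units; beyond the scatter) place isopropyl between those two groups. Going by the values given here, no measured compound shows how hexyl compares with butyl, so the guide is imperfect. A sizeable fall in the number is expected: a 19-fold lower number from compound 3 to compound 4 (1.27 log units; beyond the scatter). Compound 4 is estimated at 15 nM, with an expected range of 4 nM to 60 nM.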

Compound 4, half-maximal inhibitory concentration: 7.4 nM
Compound 4: the middle estimate sits 2.0-fold (0.31 log units) above what was measured; the range from low to high includes it.
By their numbers in this assay, from the lowest: compounds 2 and 4 (each within the scatter of the next); then compound 1; then compound 3.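

In this assay, butyl and hexyl on this aromatic carbon cannot be told apart (a 1.1-fold higher number from compound 2 to compound 4 (0.04 log units; within the scatter)), so adding to the straight chain here does not cost activity. Hexyl also gives a lower number than either branched group (a 3.9-fold lower number from compound 1 to compound 4 (0.59 log units; beyond the scatter); a 38-fold lower number from compound 3 to compound 4 (1.58 log units; beyond the scatter)), and among these four compounds the two straight chains give the lowest numbers. Nothing available here explains this difference. Still open, as far as these compounds go, is whether a longer chain, such as octyl, keeps this level of activity. A chain carrying an amine or a carboxylic acid also remains untested among the compounds shown.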